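The compounds below may be only part of what the source reports. "The series", "measured", "known", "first", "only" and "open" are said of these compounds alone.

Of the compounds shown here, three built on one shared core have been tested in an ADME assay on Vero cells (Chlorocebus sabaeus) for cytotoxicity; on this read-out higher numbers stand for lower toxicity in this test and lower numbers for higher toxicity in this test. Compound 1 `Cc1ccc2c(c1)C(=O)C(=O)N2Cc1cn(CC(=O)N2CCN(c3cc4c(cc3F)c(=O)c(C(=O)O)cn4C3CC3)CC2)nn1` gives 16 ug/mL. Compound 2 `CO/N=C1/C(=O)N(Cc2cn(CC(=O)N3CCN(c4cc5c(cc4F)c(=O)c(C(=O)O)cn5C4CC4)CC3)nn2)c2ccccc21` gives 128 ug/mL. Compound 3 `CO/N=C1/C(=O)N(Cc2cn(CC(=O)N3CCN(c4cc5c(cc4F)c(=O)c(C(=O)O)cn5C4CC4)CC3)nn2)c2ccc(F)cc21` gives 64 ug/mL, which is the second highest of the three numbers. Its nearest neighbour is compound 2, separated by a step within the scatter, and its furthest is compound 1, separated by a gap beyond the scatter. Going by the values given here, the one measured step that changes a single place is a 2.0-fold lower number from compound 2 to compound 3 (0.30 log units; within the scatter), a fluoro in place of hydrogen on an aromatic carbon.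

Compound 4 `CCO/N=C1/C(=O)N(Cc2cn(CC(=O)N3CCN(c4cc5c(cc4F)c(=O)c(C(=O)O)cn5C4CC4)CC3)nn2)c2ccc(F)cc21` has not yet been measured. It differs from compound 3 in one place: methyl in place of hydrogen on a saturated chain carbon bound to an oxygen on an unsaturated carbon. Among the compounds with values here, no measured step bears directly on this change; the only single-place step, a 2.0-fold lower number from compound 2 to compound 3 (0.30 log units; within the scatter), concerns a different group and stays within the scatter, so it offers no reason to expect a large move here. For compound 4 the expected step is no change at the digits printed from compound 3 to compound 4 (within the scatter), that is, no movement beyond the scatter. Compound 4 is therefore estimated at 64 ug/mL, with a likely range from 32 ug/mL to 128 ug/mL.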

Compound 4, half-maximal cytotoxic concentration: 8 ug/mL
Compound 4: the middle estimate sits 8.0-fold (0.90 log units) above what was measured, and the stated range ends above it.
By their numbers in this assay, from the lowest: compounds 4 and 1 (each within the scatter of the next); then compounds 3 and 2 (each within the scatter of the next).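

In this assay, going from methoxy to ethoxy gives an 8.0-fold lower number from compound 3 to compound 4 (0.90 log units; beyond the scatter). Going by these compounds alone, this place on the molecule therefore responds to very little: one added methyl, a single heavy atom, moves the number beyond the scatter, whereas the only earlier single-place step, a 2.0-fold lower number from compound 2 to compound 3 (0.30 log units; within the scatter), stayed within it. Nothing measured here accounts for this drop.

The compounds shown leave open whether the number keeps falling with a longer chain such as propoxy, or changes differently when the chain carries an amine or a carboxylic acid. They also leave open whether the same methyl would have a similar effect on compound 2, which has hydrogen where compound 3 has fluoro.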